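This account rests on a few compounds, and the source may have more. Where it says the series, first, only, none or still open, it means among the compounds named here.

Going by the values given here, in a functional assay on A549 cells (Homo sapiens) for inhibition, read by trypan blue exclusion, with a stated time of 72 h (on this read-out lower numbers stand for stronger inhibition of growth and higher numbers for weaker inhibition of growth), only two compounds have numbers so far. Compound 1 (`Cn1c(=O)c(S(=O)(=O)c2ccc(OC(=O)CCCCC3SCC4NC(=O)NC43)cc2)cc2cnc(Nc3ccc4[nH]ccc4c3)nc21`) gives 2500 nM in this test. Compound 2 (`Cn1c(=O)c(S(=O)(=O)c2ccc(F)cc2)cc2cnc(Nc3ccc4[nH]ccc4c3)nc21`) gives 200 nM and so holds the lower of the two numbers, which here means the stronger inhibition of growth. The gap between the two lies beyond the usual scatter of repeated measurements.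

The next compound to consider is compound 3 (`Cn1c(=O)c(S(=O)(=O)c2ccc(O)cc2)cc2cnc(Nc3ccc4[nH]ccc4c3)nc21`). It is compound 2 with hydroxy in place of fluoro on an aromatic carbon, para to a large group (hydroxy in place of fluoro on an aromatic carbon). Everything else in the molecule stays the same.

Among the compounds with values here, no two measured compounds differ in one place only, so the data give no direct measure of what this swap does. The change is confined to a single substituent, so only a modest shift from the value of compound 2 (200 nM) is expected. The expected step, toward slightly weaker inhibition of growth and not clearly beyond the scatter, is a 1.5-fold higher number from compound 2 to compound 3 (0.18 log units; within the scatter). For compound 3 the estimated value is 300 nM, with an expected range from 100 nM to 900 nM.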

Compound 3, concentration for 50% growth inhibition: 750 nM
Compound 3: middle estimate off by 2.5-fold (0.40 log units), on the low side, within the range that was stated.
By their numbers in this assay, from the lowest: compound 2; then compound 3; then compound 1.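

In this assay, going by these compounds alone, replacing fluoro with hydroxy on the six-membered aromatic ring, para to a large group, gives the first direct comparison at this position: a 3.8-fold higher number from compound 2 to compound 3 (0.57 log units; beyond the scatter). The position is therefore not indifferent to small changes: exchanging one heavy atom for another, with the shared core left untouched, is enough to weaken growth inhibition by a step beyond the usual scatter of repeated measurements. The hydroxy group, which adds a hydrogen-bond donor and acceptor that fluoro lacks, is the less favourable of these two groups here. Nothing measured on these compounds shows why this swap has this effect.

A single pair cannot show whether the weaker result is specific to hydroxy or would also appear with an amine, a methoxy group or a carboxylic acid at the same place. Nor can it show whether fluoro itself adds anything, as the comparison that would test this, a ring carrying plain hydrogen at this position, is not among the compounds shown.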